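Swapping an Aminophenyl for a Hydroxyphenyl on a Shared Core

This account rests on a few compounds, and the source may have more. Where it says the series, first, only, none or still open, it means among the compounds named here.

Measured so far, in an assay on isolated protein for inhibition of DNA topoisomerase 1 (Homo sapiens), with a stated time of 30 min, tested at 100 uM; on this read-out higher numbers stand for a stronger effect at the one concentration tested and lower numbers for a weaker effect:
Compound 1 `COc1ccc(-c2cc3ccccc3c(-c3cccc(N)c3)n2)cc1` gives 0%.
Compound 2 `COc1ccc(-c2cc3ccccc3c(-c3ccc(O)cc3)n2)cc1` gives 6.7%.
Compound 3 `COc1ccc(-c2cc3cc(C)ccc3c(-c3cccc(N)c3)n2)cc1OC` gives 7.2%.

Compound 1 and compound 2 differ by one change, (4-hydroxyphenyl in place of 3-aminophenyl on an aromatic carbon), and that step is a number 6.7 percentage points higher from compound 1 to compound 2 (within the scatter). Compound 3 carries a different core; how the core of compound 3 differs from the core of compound 1 is not broken down here. Compound 4 `COc1ccc(-c2cc3cc(C)ccc3c(-c3ccc(O)cc3)n2)cc1OC` is not yet measured and differs from compound 3 by 4-hydroxyphenyl in place of 3-aminophenyl on an aromatic carbon. For the measured compounds named here, this is the same kind of change as the one from compound 1 to compound 2, though the surroundings are described a little differently: in compound 1 the position is meta to a 4-methoxyphenyl group (8 heavy atoms), while in compound 3 it is meta to a large group.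

Going by the values given here, the only guide is that single earlier step. Because a number 6.7 percentage points higher from compound 1 to compound 2 (within the scatter) stayed within the scatter, the expected step from compound 3 to compound 4 is also small, a number 2.8 percentage points higher from compound 3 to compound 4 (within the scatter). Compound 4 is therefore estimated to give 10% in this assay, likely between 0% and 25%.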

Compound 4, a percentage reported as inhibition, at one concentration (the size of the read-out at that concentration, not a potency): 0.3%
For compound 4 the middle estimate is 9.7 percentage points above the measured one; measured number inside the range.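

In this assay the change to 4-hydroxyphenyl in place of 3-aminophenyl on the core of compound 3 gives a number 6.9 percentage points lower from compound 3 to compound 4 (within the scatter) and, set beside the same change on the core of compound 1, it reads as follows: the same change on two cores in this assay, a number 6.7 percentage points higher (within the scatter) from compound 1 to compound 2 and a number 6.9 percentage points lower (within the scatter) from compound 3 to compound 4, 13.6 percentage points apart, within the scatter of two such steps
The two steps point in opposite directions, but that carries no weight, and on neither core does the change make a difference that can be told from ordinary repeat variation. This does not show that the two cores truly respond alike: all four numbers lie close to the bottom of the read-out at a single concentration, and steps this small say little about how the change would behave in a compound with a clear effect.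

The compounds shown leave open whether another group at this place, such as a carboxylic acid or a longer chain ending in an amine, would give a number clear of the scatter. They also leave open what this same change does on a core that already gives clear inhibition.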